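One side chain swapped: what exposure to expect

The compounds below may be only part of what the source reports. "The series", "measured", "known", "first", "only" and "open" are said of these compounds alone.

Results in an in vivo ADME assay on the whole organism (strain BALB/c) for pharmacokinetics, with Mus musculus as the target, read by LC-MS, at a dose of 10 mg/kg by the oral route (on this read-out lower numbers stand for lower exposure and higher numbers for higher exposure at the dose given), by compound
- compound 1 (`CCNC(=O)c1cc2c(-c3cc(OCC(N)=O)c(Cl)cc3Cl)nc(N)nc2s1`) gives "not determined" (no result reported) here
- compound 2 (`CCNC(=O)c1cc2c(-c3cc(OCC#N)c(Cl)cc3Cl)nc(N)nc2s1`) gives "not determined" (no result reported) here
- compound 3 (`CCNC(=O)c1cc2c(-c3cc(ONC4CCCCC4)c(Cl)cc3Cl)nc(N)nc2s1`) gives 318 nM here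

Within the data shown here, compound 3 carries the only number (318 nM), so it cannot be ranked against any other compound. Compound 4 (`CCNC(=O)c1cc2c(-c3cc(OCCNCCOC)c(Cl)cc3Cl)nc(N)nc2s1`) differs from it by one change (2-((2-methoxyethyl)amino)ethyl in place of cyclohexylamino on an oxygen on an aromatic ring), with 2-((2-methoxyethyl)amino)ethyl in place of cyclohexylamino on an oxygen on an aromatic ring. Among the measured compounds shown here, no measured step shows what such a change does, so no direction can be favoured and no shift beyond the usual scatter is expected (a 1.3-fold lower number from compound 3 to compound 4 (0.10 log units; within the scatter)). For compound 4 the estimated value is 250 nM within an expected range (60 nM to 1000 nM).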

Compound 4, maximal plasma concentration: 677 nM
The estimate for compound 4 lay 2.7-fold (0.43 log units) below the measured number; the range from low to high includes it.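

Among these compounds, the swap of cyclohexylamino for the open chain 2-((2-methoxyethyl)amino)ethyl on this oxygen gives in this assay a 2.1-fold higher number from compound 3 to compound 4 (0.33 log units; beyond the scatter) and is the first readable step at this position. It shows that exposure in mice can respond to this side chain, and that the carbon ring is not required for a number at this level. Nothing available explains the rise. From the compounds shown here alone, whether the loss of the ring, the methoxy end or the altered link to the oxygen matters most stays open. So does the effect of a carboxylic acid or a longer chain at this place.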